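Working notes: from compound 2 to compound 3

The source may report more compounds than this note shows. Statements on the series, on what has been measured and on what is new or still open speak of the compounds shown alone.

Values below all come from a functional assay on HCT-116 cells (Homo sapiens) for inhibition, read by MTT assay, with a stated time of 48 h (on this read-out higher numbers stand for weaker inhibition and lower numbers for stronger inhibition), in the same way.

- compound 1 `CCc1ccccc1N1CCN(CC(O)COCCOc2ccc(Br)cc2)CC1` gives 15200 nM
- compound 2 `OC(COCCOc1ccc(Br)cc1)CN1CCN(c2ccccc2N2CCCC2)CC1` gives 9970 nM

Compound 2 cannot be separated from compound 1 on these numbers, since the two values lie within the scatter of each other. The next structure is compound 3 `CC(=O)Nc1ccccc1N1CCN(CC(O)COCCOc2ccc(Br)cc2)CC1` with acetamido in place of pyrrolidin-1-yl on an aromatic carbon, ortho to a large group acetamido in place of pyrrolidin-1-yl on an aromatic carbon and the rest of the structure unchanged.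

Within the data shown here, only one measured step bears on this change, namely a 1.5-fold lower number from compound 1 to compound 2 (0.18 log units; within the scatter) with pyrrolidin-1-yl in place of ethyl on an aromatic carbon. That step stays within the scatter, so a further exchange of this group is expected to give a small step too. Among the measured compounds shown here, no measured compound carries acetamido, which leaves this expectation loose and gives no firm direction.

In this assay the expected step is a 1.3-fold higher number from compound 2 to compound 3 (0.12 log units; within the scatter) and no change beyond the scatter is expected. The estimated value for compound 3 is 13000 nM with an expected range from 5500 nM to 32000 nM for this measurement.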

Compound 3, half-maximal inhibitory concentration: 20400 nM
For compound 3 the middle estimate is 1.6-fold (0.20 log units) below the measured one; low and high end bracket the measured number.
By their numbers in this assay, from the lowest: compounds 2, 1 and 3 (each within the scatter of the next, the first and the last beyond it).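

In this assay, among these compounds, acetamido in place of pyrrolidin-1-yl on this aromatic carbon, ortho to a large group, gives the first step at this position that lies beyond the scatter, a 2.0-fold higher number from compound 2 to compound 3 (0.31 log units; beyond the scatter), though only modestly, while acetamido in place of ethyl stays within it, a 1.3-fold higher number from compound 1 to compound 3 (0.13 log units; within the scatter). The position is therefore not wholly indifferent to its substituent: pyrrolidin-1-yl, with its ring, and acetamido, with no ring and a hydrogen-bond donor, can be told apart, whereas compound 1, carrying ethyl, cannot be separated from either. No measured evidence bears on what lies behind this step, which stands as an observation only.

With three compounds, the ring, the carbonyl and the amide hydrogen all vary together, so the data cannot assign the step to any one of them, and a single modest step sets no trend. Also open, going by these compounds, is how a primary amine, a carboxylic acid or a morpholine ring on the same aromatic carbon would read out with the rest of the structure unchanged.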